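Butyl to Phenyl at the Same Aromatic Carbon

A few compounds are considered here, and "the series" means these few. Any claim that something is new, unique, unknown or untested is made for them only; others in the source may bear on it.

Compound 1, `CC1CC/C(=N\Nc2ccc(I)cc2)c2ncc(C(=O)O)c(=O)n21`, gives in a functional assay on the whole organism for inhibition, with Rattus norvegicus as the target; a higher number here means that more compound is needed for the effect, a lower number that less compound is needed > 1000 umol/kg, which is a limit of the assay rather than a number.
Compound 2, `Cc1ccc(N/N=C2\CCC(C)n3c2ncc(C(=O)O)c3=O)cc1`, gives > 1000 umol/kg, again a limit of the assay.
Compound 3, `CCCCc1ccc(N/N=C2\CCC(C)n3c2ncc(C(=O)O)c3=O)cc1`, gives 100 umol/kg.

Among the compounds with values here, compound 3 therefore holds the only actual number in this assay; the other two values sit at the limit of > 1000 umol/kg in this assay, at which 2 of the 3 values shown sit. Two measured steps lead to compound 3: an at least 10-fold lower number from compound 1 to compound 3 (1.00 log units; beyond the scatter) and an at least 10-fold lower number from compound 2 to compound 3 (1.00 log units; beyond the scatter). In both, a small group at the same aromatic carbon is exchanged for butyl, and in both the number falls by a margin beyond the scatter, though its full size stays hidden behind the limit.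

Compound 4, `CC1CC/C(=N\Nc2ccc(-c3ccccc3)cc2)c2ncc(C(=O)O)c(=O)n21`, differs from compound 3 by phenyl in place of butyl on an aromatic carbon. Within the data shown here, no measured step exchanges butyl for phenyl, so the two steps above only show that a larger group at this place has so far gone together with a lower number; how far that carries to phenyl cannot be read from them. The expectation is a step of about the scatter, or a little lower, a 1.3-fold lower number from compound 3 to compound 4 (0.10 log units; within the scatter). Compound 4 is accordingly expected at 80 umol/kg, within 25 umol/kg to 300 umol/kg.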

Compound 4, dose for 50% inhibition: > 100 umol/kg
Compound 4: only a limit was reported (the forecaster's own chance of this, stated with the estimate: 15%); at least 1.2-fold (0.09 log units) between middle value and limit.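

In this assay compound 4 gives > 100 umol/kg, which is a limit of the assay and not a number. Phenyl in place of butyl gives a number no lower from compound 3 to compound 4 (the limit leaves the size open), so at this aromatic carbon a group with more heavy atoms, here carrying a ring, did not bring the number lower, and compound 4 stands against the earlier impression that larger groups go with lower numbers. The steps to compound 4 from compound 1 and from compound 2 cannot be read, since both ends of each step are limits, so the position of phenyl relative to iodo and methyl stays undecided.

Going by these compounds, how far compound 4 lies from compound 3 remains unknown, so phenyl may be only slightly worse than butyl or very much worse. The compounds shown also leave open whether a pentyl chain would continue the gain seen with butyl, and whether a cyclohexyl ring, which is saturated where phenyl is aromatic, would behave like the chain or like phenyl at this carbon.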